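Moving the Chlorine from 2-Chlorophenyl to 3-Chlorophenyl

The source may hold more compounds than are shown below. What is called first, only, known or untested is meant among the compounds shown, and "the series" means these compounds.

In a functional assay on K562 cells (Homo sapiens) for cytotoxicity, read by sulforhodamine B assay (on this read-out higher numbers stand for weaker inhibition of growth and lower numbers for stronger inhibition of growth), compound 1 `CC1=CC[C@@H]([C@@](C)(O)CCCC(C)(C)NC(=S)NN)CC1` gives 380 nM. Compound 2 `CC1=CC[C@@H]([C@@](C)(O)CCCC(C)(C)NC(=S)N/N=C\c2ccc(C)cc2)CC1` gives 7950 nM, and compound 3 `CC1=CC[C@@H]([C@@](C)(O)CCCC(C)(C)NC(=S)N/N=C\c2ccccc2Cl)CC1` gives 4110 nM. Attaching the aromatic groups accompanies large steps, namely a 21-fold higher number from compound 1 to compound 2 (1.32 log units; beyond the scatter) and an 11-fold higher number from compound 1 to compound 3 (1.03 log units; beyond the scatter). Going by the values given here, compound 3 therefore belongs with the higher numbers, and the one measured step within that pair is a 1.9-fold lower number from compound 2 to compound 3 (0.29 log units; within the scatter). Compound 4 `CC1=CC[C@@H]([C@@](C)(O)CCCC(C)(C)NC(=S)N/N=C\c2cccc(Cl)c2)CC1` differs by 3-chlorophenyl in place of 2-chlorophenyl on a carbon with a double bond to nitrogen. It keeps the aromatic group, so the large steps from the unsubstituted end of the series do not apply directly. The closest guide is the exchange of 4-methylphenyl for 2-chlorophenyl on the same carbon, which gave a 1.9-fold lower number from compound 2 to compound 3 (0.29 log units; within the scatter). No step beyond the scatter is therefore expected in this assay, and no direction can be favoured. The estimated change is a 1.2-fold higher number from compound 3 to compound 4 (0.09 log units; within the scatter). The expected value for compound 4 is 5000 nM, with an estimated range of 2300 nM to 10000 nM.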

Compound 4, concentration for total growth inhibition: 1060 nM
The estimate for compound 4 lay 4.7-fold (0.67 log units) above the measured number; the measured number lies below the stated range.
By their numbers in this assay, from the lowest: compound 1; then compound 4; then compounds 3 and 2 (each within the scatter of the next).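

In this assay, where the chlorine sits on the aromatic ring proves to matter: with the same atoms joined differently, 3-chlorophenyl in place of 2-chlorophenyl gives a step beyond the scatter (a 3.9-fold lower number from compound 3 to compound 4 (0.59 log units; beyond the scatter)), whereas the exchange of 4-methylphenyl for 2-chlorophenyl stayed within it. 3-Chlorophenyl also separates clearly from 4-methylphenyl (a 7.5-fold lower number from compound 2 to compound 4 (0.88 log units; beyond the scatter)), yet compound 4 still does not match compound 1, which has no aromatic group (a 2.8-fold higher number from compound 1 to compound 4 (0.45 log units; beyond the scatter)). Nothing measured here explains the effect of moving the chlorine.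

The compounds shown leave open whether 4-chlorophenyl or 3-methylphenyl on the same carbon would behave like 3-chlorophenyl. They also leave open whether any aromatic group there, such as one carrying an amine, could reach the value of compound 1 (380 nM).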